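The source may report more compounds than this note shows. Statements on the series, on what has been measured and on what is new or still open speak of the compounds shown alone.

Measured in a functional assay on HepG2 cells (Homo sapiens) for cytotoxicity, read by MTT assay, with a stated time of 48 h; a higher number here means a weaker inhibitor, a lower number a stronger inhibitor:
compound 1 `COc1cc(-c2nnc3n2NC(c2ccco2)C(C(=O)c2ccccc2F)S3)cc(OC)c1OC` — > 100000 nM, a limit of the assay
compound 2 `COc1cc(-c2nnc3n2NC(c2ccco2)C(C(=O)c2ccc(Cl)cc2)S3)cc(OC)c1OC` — 78600 nM

Compound 1 stands at the edge of this assay: the value of > 100000 nM for compound 1 is a limit, not a number (the limit of > 100000 nM in this assay, at which 1 of the 2 values shown sits). Compound 2 is changed only at the carbonyl carbon and gives 78600 nM in this assay, so the step of an at least 1.2-fold lower number from compound 1 to compound 2 (0.10 log units; that floor lies within the scatter) — 4-chlorophenyl in place of 2-fluorophenyl on a carbonyl carbon — stays within the scatter. Compound 3 `COc1cccc(C(=O)C2Sc3nnc(-c4cc(OC)c(OC)c(OC)c4)n3NC2c2ccco2)c1` is not yet measured; it differs from compound 1 as follows: 3-methoxyphenyl in place of 2-fluorophenyl on a carbonyl carbon. Among the compounds with values here, the only measured step that bears on it is the one from compound 1 to compound 2, which also exchanges the aryl group on the carbonyl carbon and shows no movement beyond the scatter. The step of a number no higher from compound 1 to compound 3 (the limit leaves the size open) is therefore expected to be small or none. Compound 3 is estimated at 100000 nM in this assay, with a range from 50000 nM to 300000 nM, and with a fair chance that only a limit is reported.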

Compound 3, half-maximal inhibitory concentration: > 100000 nM
Compound 3 ended at the assay's limit (the forecaster's own chance of this, stated with the estimate: 50%); the middle value lies on the limit itself.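

In this assay compound 3 gives > 100000 nM, which is a limit of the assay and not a number. Putting 3-methoxyphenyl in place of 4-chlorophenyl on the carbonyl carbon gives an at least 1.2-fold higher number from compound 2 to compound 3 (0.10 log units; that floor lies within the scatter), so a second exchange of the aryl group shows no movement beyond the scatter, while the step between compound 1 and compound 3 cannot be read, both values being limits. With three aryl groups now seen at this place, no exchange has produced a readable move beyond the scatter, and the readings gather at the top of the range: the limit of > 100000 nM in this assay, at which 2 of the 3 values shown sit.

From the compounds shown here alone, whether an amine or a carboxylic acid on the phenyl ring, or a longer chain in its place, would bring a value clearly under the limit stays open. Also open, going by these compounds, is whether a change elsewhere on the shared core would do so.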